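This account rests on a few compounds, and the source may have more. Where it says the series, first, only, none or still open, it means among the compounds named here.

Working notes on the series. Among the compounds with values here, in a functional assay on the whole organism (strain Wistar) for inhibition, with Rattus norvegicus as the target, read by paw edema, with a stated time of 2 h, at a dose of 100 mg/kg (a lower number here means less inhibition, a higher number more inhibition at the dose given (going by the name of the read-out)), compound 2 `COc1cc2c(cc1OC)C(CC(=O)Nc1ccc(Br)cc1)CC2` gives 40%, the lower of the two numbers measured so far. Compound 1 `COc1cc2c(cc1OC)C(CC(=O)Nc1ccc(Cl)cc1)CC2` gives 63% in this assay. Within the data shown here, the only measured step, a number 23 percentage points lower from compound 1 to compound 2 (beyond the scatter), is a bromo in place of chloro on an aromatic carbon. Compound 3 `COc1cc2c(cc1OC)C(CC(=O)Nc1ccncc1)CC2` differs from compound 2 by pyridin-4-yl in place of 4-bromophenyl on an amide-type nitrogen. Among the measured compounds shown here, no measured step concerns an exchange of this kind, so no direction can be read from the data and the range must stay wide. Compound 3 is expected to give 50%, within 25% to 75%. The expected step is a number 10 percentage points higher from compound 2 to compound 3 (within the scatter).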

Compound 3, a percentage reported as inhibition, in the whole organism at one dose (the size of the read-out at that dose, not a potency): 44%
The estimate for compound 3 lay 6 percentage points above the measured number, within the range that was stated.
By their numbers in this assay, from the lowest: compounds 2 and 3 (each within the scatter of the next); then compound 1.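

In this assay the amide-type nitrogen now carries a ring with a hetero atom instead of a halophenyl, and pyridin-4-yl gives a number 4 percentage points higher from compound 2 to compound 3 (within the scatter) and, against the chloro analogue, a number 19 percentage points lower from compound 1 to compound 3 (beyond the scatter) in this series. Within the data shown here, the same kind of exchange therefore reads differently against the two halophenyl groups, since only the step from compound 1 lies beyond the scatter. No measurement bearing on the reason for this is available.

Still open, as far as these compounds go, is how phenyl without a halogen, benzyl or a phenyl ring bearing a carboxylic acid would read on this amide-type nitrogen.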